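The source may hold more compounds than are shown below. What is called first, only, known or untested is meant among the compounds shown, and "the series" means these compounds.

Of the compounds shown here, two built on a shared core have been measured in a functional assay on CHO-K1 cells for antagonist activity at C-X-C chemokine receptor type 3 (Homo sapiens), read by FLIPR, with a stated time of 10 min; on this read-out lower numbers stand for stronger inhibition and higher numbers for weaker inhibition. Compound 1 `COc1ccc(-c2nc(C(F)(F)F)sc2N2CCN(C(=O)Cn3cnc4cccnc43)[C@H](C)C2)cc1` gives 13 nM in this assay. Compound 2 `CCOc1ncc(-c2nc(C(F)(F)F)sc2N2CCN(C(=O)Cn3ncc4cccnc43)[C@H](C)C2)cn1` gives 4.1 nM in this assay, the lowest of the two numbers; the gap between compound 2 and compound 1 lies beyond the usual scatter of such measurements, so compound 2 stands as the stronger inhibitor of the pair.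

The step now considered leads from compound 2 to compound 3 `CCOc1ncc(-c2nc(C(F)(F)F)sc2N2CCN(C(=O)Cn3cc(Cl)cn3)[C@H](C)C2)cn1`, which has not yet been measured. The change sits on a saturated chain carbon bound to a carbonyl carbon: a group of 6 heavy atoms (3 carbon, 2 nitrogen, 1 chlorine; one five-membered aromatic ring with 2 hetero atoms) in place of a group of 9 heavy atoms (6 carbon, 3 nitrogen; one five-membered aromatic ring with 2 hetero atoms, one six-membered aromatic ring with 1 hetero atom), on a saturated chain carbon bound to a carbonyl carbon. Within the data shown here, no measured pair of compounds shows this exchange, so nothing in the data tells how it plays out, and compound 2 at 4.1 nM is the only anchor.

A modest weakening of inhibition is expected for compound 3, of a size that may just reach beyond the scatter, giving an expected step of a 2.2-fold higher number from compound 2 to compound 3 (0.34 log units; beyond the scatter). For compound 3 a value of 9 nM is estimated in this assay, with a range from 3 nM to 30 nM.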

Compound 3, half-maximal inhibitory concentration: 5.1 nM
For compound 3 the middle estimate is 1.8-fold (0.25 log units) above the measured one, and the stated range covers the measured number.
By their numbers in this assay, from the lowest: compounds 2 and 3 (each within the scatter of the next); then compound 1.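

In this assay, putting 4-chloro-1H-pyrazol-1-yl in place of the group of 9 heavy atoms, on a saturated chain carbon bound to a carbonyl carbon, gives a 1.2-fold higher number from compound 2 to compound 3 (0.09 log units; within the scatter). In this one pair, then, a group with a single five-membered aromatic ring reads the same as one that also carries a six-membered aromatic ring, so that second ring is not required for inhibition at this level, at least when a chlorine is present. No supporting measurement is available to explain why these two different groups read alike.

The chlorine and the loss of the six-membered ring arrive in the same step, so the compounds shown cannot separate what each contributes. As far as these compounds go, it stays open how a plain pyrazol-1-yl, or a pyrazole with a methyl or nitrile group where the chlorine sits, would read, and whether 4-chloro-1H-pyrazol-1-yl would behave the same way with the 4-methoxyphenyl group of compound 1 in place of the ethoxypyrimidine of compound 3.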